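Trimming the hydroxycarbamoyl chain of compound 2

This account rests on a few compounds, and the source may have more. Where it says the series, first, only, none or still open, it means among the compounds named here.

Compound 1 `CC(C)CCc1c(OCCCCCC(=O)NO)ccc2ccc(=O)oc12`: 870 nM
Compound 2 `CC(C)CCc1c(OCCCCCCC(=O)NO)ccc2c1OC(=O)CC2`: > 30000 nM
Compound 3 `CC(C)CCc1c(OCCCCC(=O)NO)ccc2ccc(=O)oc12`: 2760 nM

All three results come from a functional assay on A549 cells (Homo sapiens) for antiproliferative activity, read by sulforhodamine B assay, with a stated time of 48 h; a lower number here means a stronger inhibitor of growth, a higher number a weaker inhibitor of growth. Compound 2 is recorded only as > 30000 nM, which is a limit of the assay and not a number. Its place on the scale is thus (the limit of > 30000 nM in this assay, at which 1 of the 3 values shown sits).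

Compound 4 `CC(C)CCc1c(OCCCCCC(=O)NO)ccc2c1OC(=O)CC2` has not yet been measured. It shares the core of compound 2, and the change is hydroxycarbamoyl in place of (hydroxycarbamoyl)methyl on a saturated chain carbon, five bonds along the chain from an oxygen on an aromatic ring. In words, hydroxycarbamoyl stands in place of (hydroxycarbamoyl)methyl on a saturated chain carbon, five bonds along the chain from an oxygen on an aromatic ring.

For the measured compounds named here, one measured step bears on this. The same replacement, made four bonds along the chain on the core of compound 1, gave a 3.2-fold higher number from compound 1 to compound 3 (0.50 log units; beyond the scatter). That step is modest but beyond the scatter, and it points towards a higher number. It was made on a different core, however, and the limit for compound 2 gives no exact starting point. No real gain in this assay is therefore expected, and the expected outcome is that the shorter chain stays in the weak region.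

The expected change is a number no higher from compound 2 to compound 4 (the limit leaves the size open).

In this assay, compound 4 is estimated at 30000 nM, with an expected range of 10000 nM to 60000 nM.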

Compound 4, concentration for 50% growth inhibition: > 30000 nM
Compound 4 was reported as a limit; the forecaster's own chance of this, stated with the estimate: 65%; the middle value sits exactly at the limit.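

In this assay compound 2 and compound 4 are both recorded only as a limit and not as a number, so no step can be read between them: the limit of > 30000 nM in this assay, at which 2 of the 4 values shown sit.

The compounds shown leave open how far either compound lies beyond that limit, and whether hydroxycarbamoyl in place of (hydroxycarbamoyl)methyl changes anything on this shared core.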